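A few compounds are considered here, and "the series" means these few. Any claim that something is new, unique, unknown or untested is made for them only; others in the source may bear on it.

Series notes. Compound 1 `CC1(C)CC(NC(=O)Nc2ccccc2Cl)c2cc(F)ccc2O1`, compound 2 `CC1(C)CC(NC(=O)Nc2ccccc2Cl)c2cc(Cl)ccc2O1` and compound 3 `CC1(C)CC(NC(=S)Nc2ccc([N+](=O)[O-])cc2)c2cc(Cl)ccc2O1` have been measured; compound 4 `CC1(C)CC(NC(=S)Nc2ccc([N+](=O)[O-])cc2)c2cc(F)ccc2O1` has not. In a functional assay on U-373MG ATCC cells (Homo sapiens) for inhibition, read by MTT assay, with a stated time of 72 h (a higher number here means a weaker inhibitor, a lower number a stronger inhibitor), compound 1 gives 40000 nM, compound 2 gives 17000 nM and compound 3 gives 3000 nM, the lowest of the three numbers. Compound 3 and compound 2 differ by a larger part of the molecule, and the difference between the two cores is not broken down here. Compound 1 and compound 2 differ in one place, (fluoro in place of chloro on an aromatic carbon), and in this assay that step is a 2.4-fold higher number from compound 2 to compound 1 (0.37 log units; beyond the scatter). Compound 4 differs from compound 3 in the same way, (fluoro in place of chloro on an aromatic carbon), and since the place is described in the same words for both pairs, the change is taken as the same one. Among the measured compounds shown here, for compound 4 in this assay a step of similar size is expected, a 2.3-fold higher number from compound 3 to compound 4 (0.37 log units; beyond the scatter), resting on the single measured example given by a 2.4-fold higher number from compound 2 to compound 1 (0.37 log units; beyond the scatter) on a different core, so the carry-over is uncertain and the range is kept wide. Compound 4 is estimated at 7000 nM, between 3000 nM and 20000 nM.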

Compound 4, half-maximal inhibitory concentration: 3000 nM
Estimate against measurement, compound 4: 2.3-fold (0.37 log units) above; the range from low to high includes it.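

In this assay, fluoro in place of chloro on an aromatic carbon of the core of compound 3 gives no change at the digits printed from compound 3 to compound 4 (within the scatter). Set beside the earlier step on the core of compound 1, the two results do not differ by more than repeated measurement allows: the same change on two cores in this assay, a 2.4-fold higher number (0.37 log units; beyond the scatter) from compound 2 to compound 1 and no change at the digits printed (within the scatter) from compound 3 to compound 4, 2.4-fold (0.37 log units) apart, within the scatter of two such steps This means the change can be carried between these two cores with no difference that can be told from scatter, but with a single pair on each core it does not show that the step has the same size on both, and it says nothing about any further core.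

Only chloro and fluoro appear at this place in the compounds shown, so the outcome with a methyl, a methoxy or a nitrile there remains open. The two cores also differ in more than one part at once, so which part of the urea and thiourea side of the molecule matters in this cell assay stays unresolved.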